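Chromone acrylamides: amide aryl swap, compound 2 to 3

A few compounds are considered here, and "the series" means these few. Any claim that something is new, unique, unknown or untested is made for them only; others in the source may bear on it.

Two compounds of the series have numbers in a functional assay on HeLa cells (Homo sapiens) for inhibition, read by MTT assay, with a stated time of 48 h; on this read-out lower numbers stand for stronger inhibition and higher numbers for weaker inhibition. Compound 1 `O=C(/C=C/c1coc2cc(O)ccc2c1=O)NCc1ccccc1` gives in this assay only a limit, > 100000 nM, which is the assay limit rather than a measured number. Within the data shown here, compound 2 `COc1cccc(NC(=O)/C=C/c2coc3cc(OC)ccc3c2=O)c1` gives in this assay 19200 nM, the only actual number so far. The other entry, as the limit of > 100000 nM in this assay, at which 1 of the 2 values shown sits, shows, is a limit, so compound 2 has no measured neighbour to be ranked against.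

Compound 3 `COc1ccc2c(=O)c(/C=C/C(=O)Nc3ccccc3C)coc2c1` is not yet measured. It differs from compound 2 in one place: 2-methylphenyl in place of 3-methoxyphenyl on an amide-type nitrogen. Among the measured compounds shown here, no step between measured compounds is known that bears on this change, so no direction is indicated beyond the scatter; the step from compound 2 to compound 3 is expected to be small, a 1.3-fold higher number from compound 2 to compound 3 (0.11 log units; within the scatter). Compound 3 is therefore estimated in this assay at 25000 nM, within a range of 8000 nM to 80000 nM.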

Compound 3, half-maximal inhibitory concentration: 7270 nM
Estimate against measurement, compound 3: 3.4-fold (0.54 log units) above; measured number below the stated range.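

In this assay, among these compounds, the aryl group on the amide-type nitrogen gives the first single-place step: a 2.6-fold lower number from compound 2 to compound 3 (0.42 log units; beyond the scatter). This position therefore affects the read-out, and the number falls with 2-methylphenyl in place of 3-methoxyphenyl, even though the entering group carries no hydrogen-bond acceptor and the leaving group carries one. Nothing at hand bears on why the number moves at this position.

The two aryl groups differ in both the substituent and its place on the ring, so the step cannot be assigned to either alone. An unsubstituted phenyl, 3-methylphenyl or 2-methoxyphenyl on the same nitrogen would separate the two, while a pyridyl ring would test whether an all-carbon aromatic ring is needed there.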